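Methyl for bromo on the anilide of a dimethoxy acid

The compounds below may be only part of what the source reports. "The series", "measured", "known", "first", "only" and "open" are said of these compounds alone.

The study starts from compound 1 `COc1cc2c(cc1OC)C(CC(=O)O)CC2`, which in a functional assay on the whole organism (strain Swiss Albino) for inhibition, with Mus musculus as the target, in the writhing test, with a stated time of 1 h, at a dose of 100 mg/kg by the oral route (a higher number here means more inhibition at the dose given (going by the name of the read-out), a lower number less inhibition), gives 44%. Compound 2 `COc1cc2c(cc1OC)C(CC(=O)Nc1ccc(Br)cc1)CC2` carries (4-bromophenyl)amino in place of hydroxy on the carbonyl carbon, and in this assay compound 2 gives 37.5%. That change amounts to a number 6.5 percentage points lower from compound 1 to compound 2 (within the scatter), so on the two numbers shown compound 2 stands together with compound 1, the two separated only by a difference within the scatter.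

Compound 3 `COc1cc2c(cc1OC)C(CC(=O)Nc1ccc(C)cc1)CC2` is the next step. It differs from compound 2 by methyl in place of bromo on an aromatic carbon. For the measured compounds named here, no measured step exchanges one substituent for another on that aromatic ring; the only step known, a number 6.5 percentage points lower from compound 1 to compound 2 (within the scatter), concerns the amide itself and was within the scatter. Nothing in these data points to a movement beyond the scatter for compound 3, so the expected step in this assay is a number 0.5 percentage points higher from compound 2 to compound 3 (within the scatter), essentially none. Compound 3 is therefore estimated to give 38% in this assay, with a range from 25% to 51%.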

Compound 3, a percentage reported as inhibition, in the whole organism at one dose (the size of the read-out at that dose, not a potency): 41.4%
Compound 3: the middle estimate sits 3.4 percentage points below what was measured; the range from low to high includes it.
By their numbers in this assay, from the lowest: compounds 2, 3 and 1 (each within the scatter of the next).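

In this assay the exchange of bromo for methyl, on an aromatic carbon para to a large group, comes to a number 3.9 percentage points higher from compound 2 to compound 3 (within the scatter) and is the first step shown that alters the aromatic ring rather than the amide itself. At this position, the two single-atom substituents therefore cannot be told apart in this read-out, at the one dose used. A second anilide now also stands with the free acid, at a number 2.6 percentage points lower from compound 1 to compound 3 (within the scatter) alongside a number 6.5 percentage points lower from compound 1 to compound 2 (within the scatter) for the bromo analogue, so for these three compounds, replacing hydroxy with either substituted phenylamino group leaves the number within the scatter, and no measurement bears on what lies behind this result.

The compounds shown leave open whether any group at this position would move the number beyond the scatter, for instance a methoxy group, a nitro group, an amine or a longer chain such as butyl. They also leave open how the unsubstituted phenylamino group, or the same substituents placed elsewhere on the aromatic ring, would compare with compound 2 and compound 3.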